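The compounds below may be only part of what the source reports. "The series", "measured", "known", "first", "only" and "open" are said of these compounds alone.

Measured compounds:
- compound 1 `Nc1ccccc1NC(=O)c1ccc(CSC(=S)N2CCN(C3CCCCC3)CC2)cc1`: 75.3%
- compound 2 `Nc1ccccc1NC(=O)c1ccc(CSC(=S)N2CCc3cc([N+](=O)[O-])ccc32)cc1`: 33.2%
- compound 3 `CCN(Cc1ccncc1)C(=S)SCc1ccc(C(=O)Nc2ccccc2N)cc1`: 85.2%

In a functional assay on MGC-803 cells (Homo sapiens) for antiproliferative activity, read by CCK-8 assay, with a stated time of 72 h, tested at 8 uM (a lower number here means a weaker effect, a higher number a stronger effect of the compound at the concentration tested), compound 1 gives 75.3%, the second highest of the three numbers. Compound 3 sits nearest, with a number higher than compound 1 but within the scatter, so no order between the two is claimed. Compound 2 lies farthest from compound 1, its number lower by a margin beyond the scatter.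

Compound 4 `Nc1ccccc1NC(=O)c1ccc(CSC(=S)N2CCN(c3ccccc3F)CC2)cc1` is not yet measured. It differs from compound 1 in one place: 2-fluorophenyl in place of cyclohexyl on an amine nitrogen in a ring. For the measured compounds named here, no pair differing in a single place has been measured, so no step size is known from the data. The step of a number 9.3 percentage points lower from compound 1 to compound 4 (within the scatter) is expected to be small, most likely none beyond the scatter, with a slight lean downward. Compound 4 is estimated at 66%, within 38% to 88%.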

Compound 4, a percentage reported as inhibition, at one concentration (the size of the read-out at that concentration, not a potency): 86.4%
Beside the measured number, compound 4's estimate is 20.4 percentage points below it; the range from low to high includes it.
By their numbers in this assay, from the lowest: compound 2; then compounds 1, 3 and 4 (each within the scatter of the next, the first and the last beyond it).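

The first single-place change read in this series, 2-fluorophenyl in place of cyclohexyl on the amine nitrogen in the ring, gives in this assay the step of a number 11.1 percentage points higher from compound 1 to compound 4 (beyond the scatter) as a modest gain. This position therefore tolerates an aromatic ring as well as a non-aromatic one, with no loss at the concentration tested. Nothing available explains the size or direction of this step.

As far as these compounds go, whether the gain follows the aromatic ring or the fluorine remains open, as a plain phenyl would separate the two. From the compounds shown here alone, how a small group such as methyl or a longer chain on the same nitrogen compares also remains open.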